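Swapping a methyl for 4-methylbenzyl on the amide side chain

A few compounds are considered here, and "the series" means these few. Any claim that something is new, unique, unknown or untested is made for them only; others in the source may bear on it.

Of the compounds shown here, two have been measured in a functional assay on HT-29 cells (Homo sapiens) for cytotoxicity, read by MTT assay, with a stated time of 24 h, tested at 0.64 ug/mL; on this read-out lower numbers stand for a weaker effect and higher numbers for a stronger effect at the one concentration tested. Compound 1, `Cn1c(-c2ccc(NC(=O)CSC3=NCCS3)cc2)nc(-c2ccccc2)c1-c1ccccc1`, gives 16.8%. Compound 2, `CCN1CCN(CC(=O)Nc2ccc(-c3nc(-c4ccccc4)c(-c4ccccc4)n3C)cc2)CC1`, gives 7.4%. On these two numbers compound 2 stands lowest, but only by a number 9.4 percentage points lower from compound 1 to compound 2 (within the scatter), so the two compounds cannot be told apart in this assay.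

Compound 3, `Cc1ccc(CN2CCN(CC(=O)Nc3ccc(-c4nc(-c5ccccc5)c(-c5ccccc5)n4C)cc3)CC2)cc1`, has not yet been measured. It differs from compound 2 in one place: 4-methylphenyl in place of methyl on a saturated chain carbon bound to an amine nitrogen in a ring. For the measured compounds named here, the only measured step, from compound 1 to compound 2, concerns a different place, on a saturated chain carbon bound to a carbonyl carbon, and it stayed within the scatter. Going by the values given here, no measured step touches the carbon bound to the ring amine nitrogen, so there is nothing in the data pointing to a shift in either direction. The expected step is therefore a number 6.6 percentage points higher from compound 2 to compound 3 (within the scatter), that is, none beyond the scatter. Compound 3 is expected to give 14% in this assay, within a range from 2% to 36%.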

Compound 3, a percentage reported as activity, at one concentration (the size of the read-out at that concentration, not a potency): 15.4%
The estimate for compound 3 lay 1.4 percentage points below the measured number; the measured number falls inside the stated range.
By their numbers in this assay, from the lowest: compounds 2, 3 and 1 (each within the scatter of the next).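

In this assay, for the compounds shown here, this is the first measured change on a saturated chain carbon bound to an amine nitrogen in a ring: putting 4-methylphenyl in place of methyl, which can also be read as ethyl becoming 4-methylbenzyl, gives a number 8 percentage points higher from compound 2 to compound 3 (within the scatter). At this one tested concentration, then, a much larger group carrying a six-membered aromatic ring can replace the small methyl without a change that stands out from the usual variation between repeat measurements, and compound 2 and compound 3 cannot be told apart. No other measurement here bears on this result, so nothing explains it.

Going by these compounds, one pair of compounds cannot show whether this place tolerates every kind of group, so it remains open whether an amine, a carboxylic acid or a longer chain there would move the number beyond the scatter. On these data alone, it also remains open whether a plain benzyl would read like 4-methylbenzyl, and whether compound 2 and compound 3 would stay indistinguishable at other concentrations.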